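Caco-2 permeability notes on a sulfonamide series

The source may report more compounds than this note shows. Statements on the series, on what has been measured and on what is new or still open speak of the compounds shown alone.

Measured so far in an ADME assay on Caco-2 cells (Homo sapiens) for permeability, in the apical to basolateral direction; a higher number here means that the compound crosses the layer faster, a lower number that the compound crosses the layer more slowly:
compound 1 `Cn1cncc1CN1CC(N(CCn2cccc2)S(=O)(=O)c2ccccn2)Cc2cc(C#N)ccc21` gives 12.4 10^-6 cm/s
compound 2 `CC(C)OC(=O)N1CCC(CN(C2Cc3cc(C#N)ccc3N(Cc3cncn3C)C2)S(=O)(=O)c2ccccn2)CC1` gives 1 10^-6 cm/s
compound 3 `Cn1cncc1CN1CC(N(Cc2cccc(-n3cccc3)c2)S(=O)(=O)c2ccccn2)Cc2cc(C#N)ccc21` gives 2.3 10^-6 cm/s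

Compound 2 stands lowest of the three numbers in this assay. Its nearest neighbour is compound 3, a 2.3-fold higher number from compound 2 to compound 3 (0.36 log units; beyond the scatter), and its furthest is compound 1, a 12-fold lower number from compound 1 to compound 2 (1.09 log units; beyond the scatter). Compound 1 and compound 3 are separated by a 5.4-fold lower number from compound 1 to compound 3 (0.73 log units; beyond the scatter). Every one of these measured steps exchanges the whole group on the saturated chain carbon bound to the sulfonamide nitrogen; the carbonyl end of the piperidine in compound 2 has not been varied anywhere in the measured set.

Compound 4 `Cn1cncc1CN1CC(N(CC2CCN(C(=O)C3CCCC3)CC2)S(=O)(=O)c2ccccn2)Cc2cc(C#N)ccc21` keeps the piperidine of compound 2 and alters only that carbonyl end: cyclopentyl in place of isopropoxy on a carbonyl carbon. Within the data shown here, none of the measured steps touches this position, so none bears directly on the change; what the series shows concerns only the group on the chain carbon. Among the measured compounds shown here, with no guide from measured compounds, the step to compound 4 in this assay is expected to be small, a 1.5-fold higher number from compound 2 to compound 4 (0.18 log units; within the scatter), with its direction uncertain and possibly within the scatter. Compound 4 is therefore estimated at 1.5 10^-6 cm/s, with a range from 0.5 10^-6 cm/s to 4.5 10^-6 cm/s.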

Compound 4, apparent permeability: 0.5 10^-6 cm/s
The estimate for compound 4 lay 3.0-fold (0.48 log units) above the measured number, within the range that was stated.
By their numbers in this assay, from the lowest: compounds 4 and 2 (each within the scatter of the next); then compound 3; then compound 1.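

In this assay, among these compounds, the exchange of isopropoxy for cyclopentyl on a carbonyl carbon gives the first reading at this end of the piperidine (a 2.0-fold lower number from compound 2 to compound 4 (0.30 log units; within the scatter)), and that step lies within the scatter, so the assay does not separate the two compounds. At this position, then, isopropoxycarbonyl can give way to cyclopentylcarbonyl, with the oxygen of the leaving group gone and a five-membered non-aromatic ring of carbon only in its place, without a step beyond the scatter; the large steps seen so far all exchange the whole group on the chain carbon. No measurement offers an explanation for this result.

This single pair, both members of which carry a neutral group free of hydrogen-bond donors, leaves open whether a dimethylamino group, a carboxylic acid or a longer chain such as n-hexyl on the same carbonyl carbon would stay within the scatter of compound 2. Also open, on these data alone, is whether replacing the carbonyl itself, for instance with a sulfonyl group, would change the number beyond the scatter in this assay.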